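Hydroxy for Fluoro on the Aryl Sulfonamide

The source may report more compounds than this note shows. Statements on the series, on what has been measured and on what is new or still open speak of the compounds shown alone.

Two compounds have results in a functional assay (plasma) for inhibition, with Oryctolagus cuniculus as the target; on this read-out lower numbers stand for stronger inhibition and higher numbers for weaker inhibition. Compound 1 `CC1(C)[C@H]2C[C@H](NC(=O)[C@H](O)C3CCCC3)[C@@H](C/C=C\CCCC(=O)O)[C@@H]1C2` reaches only a limit of the assay, > 800000 nM. In this assay compound 2 `O=C(O)CCC/C=C\C[C@H]1[C@@H]2CCC(C2)[C@@H]1NS(=O)(=O)c1ccc(F)cc1` gives 600 nM, the single number shown, so it stands as the only measured anchor. Compound 3 `O=C(O)CCC/C=C\C[C@H]1[C@@H]2CCC(C2)[C@@H]1NS(=O)(=O)c1ccc(O)cc1` differs from compound 2 by hydroxy in place of fluoro on an aromatic carbon. Among the measured compounds shown here, no step between measured compounds is available to gauge such a change, so the expected step is a 1.3-fold higher number from compound 2 to compound 3 (0.12 log units; within the scatter), a shift no larger than the usual scatter in either direction. Compound 3 is therefore estimated at 800 nM, within a range from 200 nM to 4000 nM.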

Compound 3, half-maximal inhibitory concentration: 500 nM
Estimate against measurement, compound 3: 1.6-fold (0.20 log units) above; the measured number falls inside the stated range.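

In this assay, among the compounds shown here, hydroxy in place of fluoro gives a 1.2-fold lower number from compound 2 to compound 3 (0.08 log units; within the scatter), the first step read at this position, which no earlier pair offered. On an aromatic carbon para to a large group, then, the two groups cannot be told apart on this read-out, although hydroxy brings a hydrogen-bond donor and acceptor that fluoro lacks. Nothing shown here bears on the reason for this result. As far as these compounds go, it remains open whether an amine, a methoxy group or a carboxylic acid at this position would also stay within the scatter of compound 2.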